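The compounds below may be only part of what the source reports. "The series", "measured", "known", "first", "only" and "open" are said of these compounds alone.

Compound 1 `CNC(=O)c1cc(Oc2ccc(NC(=O)c3cc4cccnc4n(-c4ccc(F)cc4)c3=O)cc2)ccn1` gives 160 nM in a functional assay on HT-29 cells (Homo sapiens) for antiproliferative activity, read by MTT assay, with a stated time of 72 h; on this read-out lower numbers stand for stronger inhibition and higher numbers for weaker inhibition.
Compound 2 `CNC(=O)c1cc(Oc2ccc(NC(=O)c3cc4cccnc4n(-c4ccc(Cl)cc4)c3=O)cc2)ccn1` gives 390 nM in this assay.
Compound 3 `CCNC(=O)c1cc(Oc2ccc(NC(=O)c3cc4cccnc4n(-c4ccc(Cl)cc4)c3=O)cc2)ccn1` gives 330 nM in this assay.

Compound 3 stands second highest of the three numbers: compound 2 lies nearest, with a 1.2-fold lower number from compound 2 to compound 3 (0.07 log units; within the scatter) within the scatter, while compound 1 gives the lowest number, its gap to compound 3 beyond the scatter. Compound 4 `CCNC(=O)c1cc(Oc2ccc(NC(=O)c3cc4cccnc4n(-c4ccc(C(F)(F)F)cc4Cl)c3=O)cc2)ccn1` differs from compound 3 by 2-chloro-4-(trifluoromethyl)phenyl in place of 4-chlorophenyl on an aromatic nitrogen. Among the compounds with values here, the only measured step touching this ring is a 2.4-fold higher number from compound 1 to compound 2 (0.39 log units; beyond the scatter), a modest rise on changing the halogen there. Within the data shown here, no measured step covers the trifluoromethyl or the second chlorine. A modest rise, or none beyond the scatter, is therefore expected for compound 4 in this assay, estimated at 450 nM with a range of 150 nM to 1400 nM. That expected step is a 1.4-fold higher number from compound 3 to compound 4 (0.13 log units; within the scatter).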

Compound 4, half-maximal inhibitory concentration: 4770 nM
The estimate for compound 4 lay 11-fold (1.03 log units) below the measured number, and the stated range ends below it.
By their numbers in this assay, from the lowest: compound 1; then compounds 3 and 2 (each within the scatter of the next); then compound 4.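

Replacing 4-chlorophenyl with 2-chloro-4-(trifluoromethyl)phenyl on the aromatic nitrogen gives a 14-fold higher number from compound 3 to compound 4 (1.16 log units; beyond the scatter) in this assay. This position can therefore respond far more strongly than the exchange of one halogen for another had shown. Nothing at hand accounts for this loss of activity. The step changes the ring in two ways at once, so the shares of the trifluoromethyl and the added chlorine cannot be told apart. From the compounds shown here alone, whether a methoxy group or an amine on this ring would retain activity also remains open.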